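A few compounds are considered here, and "the series" means these few. Any claim that something is new, unique, unknown or untested is made for them only; others in the source may bear on it.

Measured so far in a functional assay, read by Griess assay, with a stated time of 2.5 h; on this read-out lower numbers stand for stronger inhibition and higher numbers for weaker inhibition:

compound 1 `COc1cc(OC)c(OC)cc1/C=C/C(=O)c1ccc(-c2c[nH]cn2)cc1` gives 1.97 ug/mL
compound 2 `COc1cc(OC)c(OC)cc1/C=C/C(=O)c1ccc(F)cc1` gives 1.96 ug/mL
compound 3 `COc1cc(OC)c(OC)cc1/C=C/C(=O)c1ccc(O)cc1` gives 2.5 ug/mL

Compound 3 cannot be told apart from the other two, since a 1.3-fold higher number from compound 1 to compound 3 (0.10 log units; within the scatter) and a 1.3-fold higher number from compound 2 to compound 3 (0.11 log units; within the scatter) are both small. The next compound, compound 4 `COc1cc(OC)c(OC)cc1/C=C/C(=O)c1ccc([N+](=O)[O-])cc1`, changes one group on the shared core, with nitro in place of hydroxy on an aromatic carbon, para to a large group (nitro in place of hydroxy on an aromatic carbon). The best guides are the swaps already made at this same place. Alongside the two steps above, a 1.0-fold lower number from compound 1 to compound 2 (0.00 log units; within the scatter) is just as small, so three different groups here have left the number within the scatter. Nitro itself is untested, and three compounds are a thin basis. Even so, no step beyond the scatter is expected in this assay in either direction. The estimated step is a 1.1-fold lower number from compound 3 to compound 4 (0.06 log units; within the scatter) and nothing larger. For compound 4 the estimate is 2.2 ug/mL as the expected value, with 1.1 ug/mL to 4.4 ug/mL as its range.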

Compound 4, half-maximal inhibitory concentration: 1.98 ug/mL
Compound 4: middle estimate off by 1.1-fold (0.05 log units), on the high side; measured number inside the range.
By their numbers in this assay, from the lowest: compounds 2, 1, 4 and 3 (each within the scatter of the next).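

In this assay, nitro is a fourth group at this place on the aromatic ring, and the steps of a 1.3-fold lower number from compound 3 to compound 4 (0.10 log units; within the scatter) and a 1.0-fold higher number from compound 2 to compound 4 (0.00 log units; within the scatter) and a 1.0-fold higher number from compound 1 to compound 4 (0.00 log units; within the scatter) all stay within the scatter. The swap from hydroxy to nitro goes from 1 heavy atom to 3 and from 1 hydrogen-bond donor to 0, so even this change in what the group carries leaves the number within the scatter across the four compounds shown. Nothing available here explains why these four groups cannot be told apart.

As far as these compounds go, whether an amine, a carboxylic acid or a longer chain at this same place would give a step beyond the scatter stays open. Also open, from the compounds shown here alone, is whether this place would remain as insensitive if the rest of the shared core were changed.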